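Phenyl to pyridin-4-yl on two cores

This account rests on a few compounds, and the source may have more. Where it says the series, first, only, none or still open, it means among the compounds named here.

Compound 1 `CCNS(=O)(=O)c1ccc(NC2CC3CCC2C3)c(NCc2ccccc2)c1` and compound 3 `CNS(=O)(=O)c1ccc(NC2CCCCC2)c(NCc2ccccc2)c1` are built on different cores; the difference between the two cores is not broken down here. In a functional assay (IMR-32 cells, Homo sapiens) for inhibition, read by fluorescence, with stated times of 1 h and 13 h (a higher number here means a weaker inhibitor, a lower number a stronger inhibitor), compound 1 gives 3 nM and compound 3 gives 3.7 nM, two values that lie within the scatter of each other. Compound 2 `CCNS(=O)(=O)c1ccc(NC2CC3CCC2C3)c(NCc2ccncc2)c1` differs from compound 1 in one place: pyridin-4-yl in place of phenyl on a saturated chain carbon bound to a nitrogen on an aromatic ring. In this assay, within the data shown here, compound 2 gives 9.4 nM, so that the step of a 3.1-fold higher number from compound 1 to compound 2 (0.50 log units; beyond the scatter) is the single measured instance of this change among the compounds here.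

Compound 4 `CNS(=O)(=O)c1ccc(NC2CCCCC2)c(NCc2ccncc2)c1` is not yet measured. It stands to compound 3 exactly as compound 2 stands to compound 1: pyridin-4-yl in place of phenyl on a saturated chain carbon bound to a nitrogen on an aromatic ring. The place of the change is described in the same words for both pairs, so it is the same change, carried onto the core of compound 3.

Expectation for compound 4 in this assay: the step from compound 3 is expected to be of the size a 3.0-fold higher number from compound 3 to compound 4 (0.47 log units; beyond the scatter), because the same change on the other core gave a 3.1-fold higher number from compound 1 to compound 2 (0.50 log units; beyond the scatter). Among the measured compounds shown here, only one measured pair supports this, and nothing shows whether the change carries over between the two cores, so the range is kept wide. Compound 4 is therefore expected to give about 11 nM, with the number estimated to fall between 5 nM and 25 nM.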

Compound 4, half-maximal inhibitory concentration: 15 nM
For compound 4 the middle estimate is 1.4-fold (0.13 log units) below the measured one; measured number inside the range.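

In this assay, pyridin-4-yl in place of phenyl on a saturated chain carbon bound to a nitrogen on an aromatic ring gives a 4.1-fold higher number from compound 3 to compound 4 (0.61 log units; beyond the scatter), and this step can be set beside the one on the other core: the same change on two cores in this assay, a 3.1-fold higher number (0.50 log units; beyond the scatter) from compound 1 to compound 2 and a 4.1-fold higher number (0.61 log units; beyond the scatter) from compound 3 to compound 4, 1.3-fold (0.11 log units) apart, within the scatter of two such steps. On these two cores the change therefore points the same way, towards a weaker inhibitor, and the two steps cannot be told apart in size, so for this pair of cores the step measured on the core of compound 1 carries over to the core of compound 3. This rests on two pairs only: it shows nothing about a third core, and the numbers alone do not say why the change weakens inhibition or which part of either core, if any, bears on the size of the step.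

Only phenyl and pyridin-4-yl stand at this place in the compounds shown, so it remains open whether pyridin-3-yl, pyridin-2-yl or a phenyl carrying a methoxy group would give a step of similar size. Also open, as far as these compounds go, is whether a longer chain in place of the single saturated carbon would leave the step unchanged on either core.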